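Moving from trimethylphenyl to ethylphenyl on the shared core

A few compounds are considered here, and "the series" means these few. Any claim that something is new, unique, unknown or untested is made for them only; others in the source may bear on it.

In an assay for inhibition of protein disulfide-isomerase (Homo sapiens), with a stated time of 1 h (on this read-out lower numbers stand for stronger inhibition and higher numbers for weaker inhibition), compound 3 `Cc1cc(C)c(C(Nc2ccccn2)c2ccc3cccnc3c2O)c(C)c1` gives 190 nM, the lowest of the three numbers. Compound 1 `Oc1c(C(Nc2ccccn2)c2ccccc2F)ccc2cccnc12` gives 470 nM and compound 2 `Oc1c(C(Nc2ccccn2)c2c(Cl)cccc2Cl)ccc2cccnc12` gives 1890 nM; the measured steps are a 2.5-fold lower number from compound 1 to compound 3 (0.39 log units; beyond the scatter), a 9.9-fold lower number from compound 2 to compound 3 (1.00 log units; beyond the scatter) and a 4.0-fold higher number from compound 1 to compound 2 (0.60 log units; beyond the scatter). Compound 4 `CCc1ccc(C(Nc2ccccn2)c2ccc3cccnc3c2O)cc1` carries the change (4-ethylphenyl in place of 2,4,6-trimethylphenyl on a saturated chain carbon bound to an aromatic carbon and a nitrogen on an aromatic ring). All three measured steps swap one ring for another at this same position, and each moved the result beyond the scatter, so the swap to compound 4 is unlikely to be neutral. Since compound 3 sits lowest, a move away from it is expected to raise the number modestly: the estimated step is a 2.4-fold higher number from compound 3 to compound 4 (0.37 log units; beyond the scatter). For compound 4 in this assay the expected value is 450 nM, within a range from 150 nM to 1400 nM.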

Compound 4, half-maximal inhibitory concentration: 170 nM
Compound 4: middle estimate off by 2.6-fold (0.42 log units), on the high side, and the stated range covers the measured number.
By their numbers in this assay, from the lowest: compounds 4 and 3 (each within the scatter of the next); then compound 1; then compound 2.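

The 4-ethylphenyl ring takes the place of 2,4,6-trimethylphenyl with a 1.1-fold lower number from compound 3 to compound 4 (0.05 log units; within the scatter), so two differently substituted, halogen-free rings cannot be told apart at this position. This extends the gap from the halogen-bearing rings to a second ring, with a 2.8-fold lower number from compound 1 to compound 4 (0.44 log units; beyond the scatter) and an 11-fold lower number from compound 2 to compound 4 (1.05 log units; beyond the scatter). No available evidence explains this pattern.

Going by these compounds, whether a ring carrying an amine or a carboxylic acid would fit the same pattern remains open. So does the outcome for a longer chain in place of the ethyl group.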